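This account rests on a few compounds, and the source may have more. Where it says the series, first, only, none or still open, it means among the compounds named here.

Working notes on the series. Going by the values given here, compound 1 `O=C(CN(c1nc(Cl)nc2[nH]cnc12)C1CC1)N[C@@H](CO)C(=O)OCc1ccccc1` is the reference point: in a functional assay on the whole organism (Tail, strain ICR) with Mus musculus as the target, in the tail flick test, with a stated time of 120 min, at a dose of 25 umol/kg by the oral route (on this read-out higher numbers stand for a stronger effect at the one dose given and lower numbers for a weaker effect), compound 1 gives 34.5%, the highest of the three numbers so far. Compound 2 `O=C(CN(c1ncnc2c1ncn2C1CCCCO1)C1CC1)N[C@@H](CCC(=O)OCc1ccccc1)C(=O)OCc1ccccc1` carries a different core and gives 20.7% in this assay; compound 3 `O=C(CN(c1ncnc2c1ncn2C1CCCCO1)C1CC1)NCC(=O)OCc1ccccc1` gives 17.2%. Among the compounds with values here, both of these values lie beyond the scatter below that of compound 1, though no single-point step connects either to compound 1. Within the data shown here, the only step inside the set, a number 3.5 percentage points lower from compound 2 to compound 3 (within the scatter), concerns the group on a saturated chain carbon bound to an amide-type nitrogen and a carbonyl carbon, and it stayed within the scatter.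

Compound 4 `C[C@@H](O)[C@H](NC(=O)CN(c1nc(Cl)nc2[nH]cnc12)C1CC1)C(=O)OCc1ccccc1` differs from compound 1 by methyl in place of hydrogen on a saturated chain carbon bound to an oxygen on a saturated carbon and a saturated chain carbon. Among the measured compounds shown here, no measured pair touches this position, so the step is without a direct precedent; the one side-chain step in hand was small, which gives no ground to expect a move beyond the scatter here in either direction. Compound 4 is therefore expected to give about 32% in this assay, within 18% to 46%. The expected step of a number 2.5 percentage points lower from compound 1 to compound 4 (within the scatter) is estimated to stay within the scatter.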

Compound 4, a percentage reported as activity, at one dose (the size of the read-out at that dose, not a potency): 30.7%
The estimate for compound 4 lay 1.3 percentage points above the measured number; measured number inside the range.
By their numbers in this assay, from the lowest: compounds 3, 2, 4 and 1 (each within the scatter of the next, the first and the last beyond it).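

In this assay, the change from hydroxymethyl to 1-hydroxyethyl gives a number 3.8 percentage points lower from compound 1 to compound 4 (within the scatter) and so shows that methyl in place of hydrogen at this place leaves the read-out at the one dose given indistinguishable from that of compound 1. Going by these compounds alone, the earlier compounds held no pair at this place, on a saturated chain carbon bound to an oxygen on a saturated carbon and a saturated chain carbon, and their one step, a number 3.5 percentage points lower from compound 2 to compound 3 (within the scatter) on a different core, concerned another group, so this is the first single-point reading on the core of compound 1. No measurement at hand speaks to why this change has so small an effect.

Open, going by these compounds, is whether a longer chain such as ethyl or propyl at this place, or an amine or a carboxylic acid in place of the hydroxyl, would also stay within the scatter of compound 1 or would move the number beyond it. Also open, on these data alone, is whether methyl in place of hydrogen at this place would read the same on the core of compound 2 and compound 3.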